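The source may hold more compounds than are shown below. What is called first, only, known or untested is meant among the compounds shown, and "the series" means these compounds.

Working notes on the series. In a functional assay on CRL2813 cells (Homo sapiens) for cytotoxicity, read by sulforhodamine B assay, with a stated time of 5 days (on this read-out lower numbers stand for stronger inhibition and higher numbers for weaker inhibition), compound 1 `O=C(Nc1ccccc1[N+](=O)[O-])N[C@H]1CC[C@H](Oc2ccc(F)cc2)CC1` gives 3500 nM, compound 2 `O=C(Nc1cccc(Cl)c1)N[C@H]1CC[C@H](Oc2ccc(F)cc2)CC1` gives 5900 nM, and compound 3 `O=C(Nc1ccccc1)N[C@H]1CC[C@H](Oc2ccc(F)cc2)CC1` gives 20000 nM, the highest number of the three; the step of a 5.7-fold higher number from compound 1 to compound 3 (0.76 log units; beyond the scatter) and the step of a 3.4-fold higher number from compound 2 to compound 3 (0.53 log units; beyond the scatter) both exceed the scatter, while the step of a 1.7-fold higher number from compound 1 to compound 2 (0.23 log units; within the scatter) does not. Compound 4 `O=C(Nc1ccccc1Cl)N[C@H]1CC[C@H](Oc2ccc(F)cc2)CC1` differs from compound 3 by chloro in place of hydrogen on an aromatic carbon, giving a 2-chlorophenyl where compound 2 carries a 3-chlorophenyl. The step of a 3.4-fold higher number from compound 2 to compound 3 (0.53 log units; beyond the scatter) bears most directly, run in reverse; the step of a 5.7-fold higher number from compound 1 to compound 3 (0.76 log units; beyond the scatter) points the same way for a 2-nitrophenyl. A lowering step of modest size is therefore expected for compound 4 in this assay, about a 4.0-fold lower number from compound 3 to compound 4 (0.60 log units; beyond the scatter), giving an estimate of 5000 nM with a range of 2000 nM to 14000 nM.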

Compound 4, half-maximal inhibitory concentration: 9100 nM
Estimate against measurement, compound 4: 1.8-fold (0.26 log units) below, within the range that was stated.
By their numbers in this assay, from the lowest: compounds 1, 2 and 4 (each within the scatter of the next, the first and the last beyond it); then compound 3.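

A chloro ortho to a large group also lowers the number relative to hydrogen (a 2.2-fold lower number from compound 3 to compound 4 (0.34 log units; beyond the scatter)), so the lowering seen with the 3-chlorophenyl and the 2-nitrophenyl is matched by the 2-chlorophenyl. The 2-chlorophenyl and 3-chlorophenyl cannot be told apart (a 1.5-fold higher number from compound 2 to compound 4 (0.19 log units; within the scatter)), whereas the exchange of nitro for chloro at this place is resolved (a 2.6-fold higher number from compound 1 to compound 4 (0.41 log units; beyond the scatter)). Nothing measured here explains these steps. From the compounds shown here alone, whether a methoxy, an amine or a carboxylic acid at this place would also lower the number remains open. Also open, going by these compounds, is whether the chloro step holds on a different core.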